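Hydroxy in place of methylsulfanyl on a triazine-fused core

The compounds below may be only part of what the source reports. "The series", "measured", "known", "first", "only" and "open" are said of these compounds alone.

Compound 1, `COCc1ncc2cnnc(O)n12`, in a functional assay for inhibition, with Homo sapiens as the target; a lower number here means a stronger inhibitor, a higher number a weaker inhibitor: > 48000 nM.
Compound 2, `CCCc1ncc2cnnc(SC)n12`, in this assay: > 48000 nM.

For compound 2 this assay reports only a limit, > 48000 nM, not a number. For compound 1 the same holds, as its value is a limit as well. Among the measured compounds shown here, both measured values therefore sit at one edge (the limit of > 48000 nM in this assay, at which 2 of the 2 values shown sit), and there is no step between them to weigh.

Compound 3, `CCCc1ncc2cnnc(O)n12`, differs from compound 2 in one place: hydroxy in place of methylsulfanyl on an aromatic carbon. With both neighbours at the limit, no step beyond the usual scatter is expected, and the change implied is a step that the limit leaves unreadable from compound 2 to compound 3. Compound 3 is thus estimated at 100000 nM, within 30000 nM to 500000 nM, most likely again reported only as a limit.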

Compound 3, half-maximal inhibitory concentration: > 48000 nM
Compound 3 ended at the assay's limit; the forecaster's own chance of this, stated with the estimate: 85%; the middle value is on the limit's open side.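

Among the compounds shown here, compound 3 also returns only a limit, so no step among compound 1, compound 2 and compound 3 can be read in this assay: the limit of > 48000 nM in this assay, at which 3 of the 3 values shown sit. The compounds shown leave open how strongly any of the three inhibits, and whether either change alters this at all.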